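The source may hold more compounds than are shown below. What is called first, only, known or untested is meant among the compounds shown, and "the series" means these compounds.

Working notes on the series. Compound 1 `COc1ccc(NC(=O)NCCCOc2cccc(CN3CCCCC3)c2)c(OC)c1` gives 2240 nM in an assay on isolated protein for inhibition of histamine H2 receptor (Cavia porcellus); a lower number here means tighter binding, a higher number weaker binding. Compound 2 `COc1ccc(OC)c(NC(=O)NCCCOc2cccc(CN3CCCCC3)c2)c1` gives 158 nM in this assay, and compound 3 `CCC(C)NC(=O)NCCCOc1cccc(CN2CCCCC2)c1` gives 95.5 nM. Among these three, compound 3 carries the lowest number, but its gap to compound 2 is within the scatter, so the two are not separated; only compound 1 stands clearly apart. For the measured compounds named here, the steps so far: a 14-fold lower number from compound 1 to compound 2 (1.15 log units; beyond the scatter); a 23-fold lower number from compound 1 to compound 3 (1.37 log units; beyond the scatter); a 1.7-fold lower number from compound 2 to compound 3 (0.22 log units; within the scatter).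

Compound 4 `CC(C)(C)NC(=O)NCCCOc1cccc(CN2CCCCC2)c1` has not been measured. It differs from compound 3 by tert-butyl in place of sec-butyl on an amide-type nitrogen. All three measured steps exchange the group on this same amide-type nitrogen, and the large ones, a 14-fold lower number from compound 1 to compound 2 (1.15 log units; beyond the scatter) and a 23-fold lower number from compound 1 to compound 3 (1.37 log units; beyond the scatter), involve the 2,4-dimethoxyphenyl group; the exchange of 2,5-dimethoxyphenyl for sec-butyl, a 1.7-fold lower number from compound 2 to compound 3 (0.22 log units; within the scatter), stayed within the scatter. Going by the values given here, no measured step exchanges one four-carbon group for another, so the expectation rests on that latter step and on the two groups having the same atoms, joined differently: no step beyond the scatter is expected in this assay. Compound 4 is therefore expected near 110 nM, within 45 nM to 270 nM. That amounts to an expected step of a 1.2-fold higher number from compound 3 to compound 4 (0.06 log units; within the scatter).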

Compound 4, dissociation constant: 2090 nM
Compound 4: middle estimate off by 19-fold (1.28 log units), on the low side; measured number above the stated range.
By their numbers in this assay, from the lowest: compounds 3 and 2 (each within the scatter of the next); then compounds 4 and 1 (each within the scatter of the next).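

In this assay the amide-type nitrogen turns out to be sensitive to the way a group's carbons are joined: a 22-fold higher number from compound 3 to compound 4 (1.34 log units; beyond the scatter) is a change with the same atoms on both sides, so the composition of the group does not settle the number at this position. Exchange for the 2,5-dimethoxyphenyl group gives a 13-fold higher number from compound 2 to compound 4 (1.12 log units; beyond the scatter) as a large step, whereas exchange for the 2,4-dimethoxyphenyl group gives a 1.1-fold lower number from compound 1 to compound 4 (0.03 log units; within the scatter) within the scatter, so the high and low numbers do not divide the dimethoxyphenyl groups from the butyl groups. Nothing among the data shown explains why tert-butyl differs so much from sec-butyl.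

Open, on these data alone, is where the number changes along the series from sec-butyl to tert-butyl, which isopropyl, n-butyl or cyclobutyl on this nitrogen would help to place. As far as these compounds go, it also remains open whether a tert-butyl group on the same nitrogen gives a similar step on any other core.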